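Positional swap of carboxy and chloro on the aryl ether

The source may report more compounds than this note shows. Statements on the series, on what has been measured and on what is new or still open speak of the compounds shown alone.

Measured compounds:
compound 1 `Cc1c(OCCCCOc2ccc(Cl)c(C(=O)O)c2)ccc(C(=O)CC(C)(C)C)c1O`, 130 nM
compound 2 `Cc1ccc(C(=O)O)cc1OCCCCOc1ccc(C(=O)CC(C)(C)C)c(O)c1C`, 892 nM
compound 3 `Cc1c(OC[C@@H](C)COc2ccc(Cl)c(C(=O)O)c2)ccc(C(=O)CC(C)(C)C)c1O`, 2200 nM

In an assay for positive allosteric modulation of metabotropic glutamate receptor 3 (Rattus norvegicus) (a higher number here means that more compound is needed for the effect, a lower number that less compound is needed), compound 3 gives 2200 nM, the highest number of the three, beyond the scatter against compound 2 and further still against compound 1.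

Compound 4 `Cc1c(OC[C@@H](C)COc2ccc(C(=O)O)c(Cl)c2)ccc(C(=O)CC(C)(C)C)c1O` differs from compound 3 by 4-carboxy-3-chlorophenyl in place of 3-carboxy-4-chlorophenyl on an oxygen on a saturated carbon.

Among the measured compounds shown here, no measured step exchanges the positions of the carboxy and chloro groups on this aryl ether, so none bears on the change directly. For the measured compounds named here, the only step that alters the aryl ether at all is a 6.9-fold higher number from compound 1 to compound 2 (0.84 log units; beyond the scatter), a modest loss on a different linker and with a different replacement group; it shows only that this assay responds to the substitution pattern of that ring. On that basis a modest change is expected for compound 4, most likely a further loss, with the direction uncertain, a 1.8-fold higher number from compound 3 to compound 4 (0.26 log units; within the scatter).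

Compound 4 is estimated at 4000 nM, range 1000 nM to 15000 nM.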

Compound 4, half-maximal effective concentration: 860 nM
Compound 4: the middle estimate sits 4.7-fold (0.67 log units) above what was measured; measured number outside the range, below it.
By their numbers in this assay, from the lowest: compound 1; then compounds 4 and 2 (each within the scatter of the next); then compound 3.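

In this assay, moving the carboxy and chloro groups gives a 2.6-fold lower number from compound 3 to compound 4 (0.41 log units; beyond the scatter) on the chain of compound 3, so 4-carboxy-3-chlorophenyl is preferred to 3-carboxy-4-chlorophenyl on this chain. Among the compounds shown here, this is the first comparison in which the entering and leaving groups hold the same atoms, which shows that the arrangement of the two substituents alone can shift the number beyond the scatter. Nothing available explains the size or direction of this step.

From the compounds shown here alone, whether the same exchange has the same effect on the chain of compound 1 remains open. Also open, going by these compounds, is how the 4-carboxy-3-chlorophenyl ring would respond to a tetrazole in place of the carboxy group or a fluorine in place of the chlorine.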